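Swapping a Benzoyl for Naphthalenyl on a Sulfonamide Nitrogen

The compounds below may be only part of what the source reports. "The series", "measured", "known", "first", "only" and "open" are said of these compounds alone.

Compound 2 `O=C(NS(=O)(=O)c1ccc2nc(-c3ccccc3)c(-c3ccccc3)nc2c1)c1ccccc1` is the higher of the two compounds measured in an ADME assay on the whole organism for pharmacokinetics, with Homo sapiens as the target; a lower number here means that a smaller share of the oral dose reaches the circulation, a higher number that a larger share of the oral dose reaches the circulation: compound 2 gives 100%, while compound 1 `O=C(O)c1ccccc1NS(=O)(=O)c1ccc2nc(-c3ccccc3)c(-c3ccccc3)nc2c1` gives 83.6%. For the measured compounds named here, the only step seen so far, a number 16.4 percentage points higher from compound 1 to compound 2 (beyond the scatter), changed a different group than the one now in question. Compound 3 `O=S(=O)(Nc1ccc2ccccc2c1)c1ccc2nc(-c3ccccc3)c(-c3ccccc3)nc2c1` differs from compound 2 by naphthalen-2-yl in place of benzoyl on a sulfonamide nitrogen. Going by the values given here, no measured step mirrors this change, and compound 2 already sits at the top of the scale, so the number can only stay or fall. Compound 3 is expected to show a number 15 percentage points lower from compound 2 to compound 3 (beyond the scatter), a modest drop, with an estimate of 85% and a range from 60% to 100%.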

Compound 3, oral bioavailability: 100%
Beside the measured number, compound 3's estimate is 15 percentage points below it, and the stated range covers the measured number.
By their numbers in this assay, from the lowest: compound 1; then compounds 2 and 3 (each within the scatter of the next).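

In this assay the sulfonamide nitrogen takes naphthalen-2-yl in place of benzoyl with no change at the digits printed from compound 2 to compound 3 (within the scatter) and so the carbonyl of benzoyl is not needed to keep this number. Putting naphthalen-2-yl in place of 2-carboxyphenyl gives a number 16.4 percentage points higher from compound 1 to compound 3 (beyond the scatter) and this matches the step to the benzoyl compound, so two different groups lead to the same printed number. No evidence here explains this match. Both compounds sit at the top of the scale, so any difference between them above it cannot be seen. Going by these compounds, whether a simple amine or a longer alkyl chain on this nitrogen would keep the number remains open.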